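Swapping an Amide for a Sulfonamide on a Shared Core

A few compounds are considered here, and "the series" means these few. Any claim that something is new, unique, unknown or untested is made for them only; others in the source may bear on it.

Compound 1 `CC(=O)N[C@@H]1CCCc2c1cncc2N1C(=O)c2ccc(Cl)cc2[C@H]1C`: 130 nM
Compound 2 `CCC(=O)N[C@@H]1CCCc2c1cncc2N1CCc2cc(Cl)ccc2C1=O`: 119 nM

Of the compounds shown here, two have been tested in an assay on cells for inhibition of cytochrome P450 11B2, mitochondrial (Homo sapiens), read by HTRF; a lower number here means a stronger inhibitor, a higher number a weaker inhibitor. Compound 2 gives 119 nM, the lower of the two numbers, but compound 1 with 130 nM lies within the scatter of it, so the two cannot be told apart on these data. Compound 3 `CS(=O)(=O)N[C@@H]1CCCc2c1cncc2N1CCc2cc(Cl)ccc2C1=O` differs from compound 2 in one place: methylsulfonyl in place of propanoyl on an amine nitrogen. For the measured compounds named here, no measured pair shows this particular change, so the data give no direct guide to its outcome. The expectation for compound 3 is therefore a modest shift, if any, in the direction of a somewhat weaker inhibitor, with a real chance that it stays within the scatter of compound 2. Compound 3 is thus estimated to give 200 nM, within a range from 80 nM to 500 nM. That estimate amounts to an expected step of a 1.7-fold higher number from compound 2 to compound 3 (0.23 log units; within the scatter).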

Compound 3, half-maximal inhibitory concentration: 76 nM
The estimate for compound 3 lay 2.6-fold (0.42 log units) above the measured number; the whole stated range lies above it.
By their numbers in this assay, from the lowest: compounds 3, 2 and 1 (each within the scatter of the next).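

The nitrogen position accepts a clear change of chemical group without a readable change in this assay (the swap gives a 1.6-fold lower number from compound 2 to compound 3 (0.19 log units; within the scatter)). Methylsulfonyl brings sulfur and a second oxygen in place of the three carbons and one oxygen of propanoyl, yet on these numbers, the two groups cannot be told apart, so this amide-type carbonyl is not shown to be needed for inhibition at this level. No available measurement explains this result.

The compounds shown leave open how a longer chain on the sulfonyl, such as ethylsulfonyl, or a free amine at this nitrogen would behave. They also leave open whether methylsulfonyl would give a similar result on the core of compound 1.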